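The source may hold more compounds than are shown below. What is called first, only, known or untested is meant among the compounds shown, and "the series" means these compounds.

Working notes on the series. a physicochemical assay for solubility, read by LC-MS, in phosphate buffer, with a stated time of 24 h, at pH 7.4 (a higher number here means a more soluble compound, a lower number a less soluble compound), has been run on two members so far. Compound 1 `Cc1cc(-c2cnc(NCc3c(F)ccc4c3CCO4)c3cn[nH]c(=O)c23)n(C)n1` gives 1000 nM in this assay. Compound 2 `O=C1CCCN1c1cnc(NCc2c(F)ccc3c2CCO3)n2cnnc12` gives 640000 nM in this assay, the higher of the two numbers, and its gap to compound 1 lies beyond the scatter.

Compound 3 `CN(c1ccn(C)n1)c1cnc(NCc2c(F)ccc3c2CCO3)n2cnnc12` is not yet measured. It differs from compound 2 in one place: methyl(1-methyl-1H-pyrazol-3-yl)amino in place of 2-oxopyrrolidin-1-yl on an aromatic carbon. Within the data shown here, no measured pair in the set shows this change, so the step is an expectation only. The step from compound 2 to compound 3 is expected to run downward, beyond the scatter, at a 6.4-fold lower number from compound 2 to compound 3 (0.81 log units; beyond the scatter). For compound 3 the estimate in this assay is 100000 nM, with a range from 20000 nM to 400000 nM.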

Compound 3, solubility: 130000 nM
Estimate against measurement, compound 3: 1.3-fold (0.11 log units) below; low and high end bracket the measured number.
By their numbers in this assay, from the lowest: compound 1; then compound 3; then compound 2.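

Among these compounds, at this place, on an aromatic carbon of the six-membered aromatic ring, the swap of 2-oxopyrrolidin-1-yl for methyl(1-methyl-1H-pyrazol-3-yl)amino gives a 4.9-fold lower number from compound 2 to compound 3 (0.69 log units; beyond the scatter) in this assay and is the first single-place step. Even with this step, compound 3 gives 130000 nM with the larger, aromatic group in place. No measured evidence bears on the reason for this step. The compounds shown leave open whether the lactam carbonyl, the pyrazole ring or the methyl on nitrogen accounts for the step. They also leave open how a simple amine or a carboxylic acid would read on this carbon.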